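Replacing a Phenol with a Fluorophenyl Urea Extension

The source may report more compounds than this note shows. Statements on the series, on what has been measured and on what is new or still open speak of the compounds shown alone.

Of the compounds shown here, three built on one shared core have so far been tested in a functional assay on NCI-H460 cells (Homo sapiens) for inhibition, read by MTT assay, with a stated time of 72 h; a higher number here means a weaker inhibitor, a lower number a stronger inhibitor. Compound 1 `COc1cc(NC(C)CCCNC(=O)NNC(=O)Nc2cccc(F)c2)c2ncccc2c1` gives 50000 nM. Compound 2 `COc1cc(NC(C)CCCNC(=O)NNC(=O)Nc2cc(C(F)(F)F)cc(C(F)(F)F)c2)c2ncccc2c1` gives 18000 nM. Compound 3 `COc1cc(NC(C)CCCNC(=O)Nc2ccc(O)cc2)c2ncccc2c1` gives 34000 nM. In this assay the number for compound 3 lies close to those of compound 1 and compound 2, and all three fall within the usual scatter of one another, so none of them can be called stronger or weaker than the others.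

Compound 4 `COc1cc(NC(C)CCCNC(=O)NNC(=O)Nc2ccc(F)cc2)c2ncccc2c1` has not yet been measured. It differs from compound 3 in one place: ((4-fluorophenyl)carbamoyl)amino in place of 4-hydroxyphenyl on an amide-type nitrogen. For the measured compounds named here, only one measured step speaks to this kind of change, and it runs in the opposite direction: a 1.5-fold lower number from compound 1 to compound 3 (0.17 log units; within the scatter). That step was within the scatter. Compound 4 carries the same type of extension as compound 1 and compound 2, whose numbers sit on either side of the number for compound 3, so the outcome is expected to stay within the scatter, if anything drifting slightly toward the number of compound 1.

Compound 4 is therefore estimated at 40000 nM, with a likely range from 15000 nM to 100000 nM, which means an expected step of a 1.2-fold higher number from compound 3 to compound 4 (0.07 log units; within the scatter).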

Compound 4, half-maximal inhibitory concentration: > 100000 nM
Compound 4 gave a limit, no number; the forecaster's own chance of this, stated with the estimate: 10%; middle value at least 2.5-fold (0.39 log units) away from the limit.
By their numbers in this assay, from the lowest: compounds 2, 3 and 1 (each within the scatter of the next, the first and the last beyond it). At a limit, above all of these: compound 4.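

In this assay compound 4 gives > 100000 nM, which is a limit and not a number, and it stands alone there: the limit of > 100000 nM in this assay, at which 1 of the 4 values shown sits. Putting ((4-fluorophenyl)carbamoyl)amino in place of 4-hydroxyphenyl on the amide-type nitrogen gives an at least 2.9-fold higher number from compound 3 to compound 4 (0.46 log units; beyond the scatter), so at this position the swap can shift the result measurably, which the earlier step between the same two kinds of group, a 1.5-fold lower number from compound 1 to compound 3 (0.17 log units; within the scatter), did not show. Exchanging 3-fluorophenyl for 4-fluorophenyl on the same extension gives an at least 2.0-fold higher number from compound 1 to compound 4 (0.30 log units; that floor lies within the scatter), so these two fluorophenyl groups may differ, but the floor of that step does not establish a difference on its own.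

Going by these compounds, the true number for compound 4 remains unknown, which leaves the full size of both new steps open, including whether the step between the two fluorophenyl groups is in fact larger than the scatter. Also open, on these data alone, is whether a 4-chlorophenyl group or an unsubstituted phenyl group on the same extension would give a measurable number or would reach the same limit.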